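The source may hold more compounds than are shown below. What is called first, only, known or untested is meant among the compounds shown, and "the series" means these compounds.

The measured compounds:
compound 1, `CCCCCCC#Cc1ccc(S(=O)(=O)Nc2cccc(-c3csc(NC(C)=O)n3)c2)cc1`, 40.7%
compound 2, `CC(=O)Nc1nc(-c2cccc(NS(=O)(=O)c3ccc(C#CCO)cc3)c2)cs1`, 81.3%

In a functional assay on A-375 cells (Homo sapiens) for antiproliferative activity, read by trypan blue exclusion, with a stated time of 48 h, tested at 1 uM (a higher number here means a weaker effect of the compound at the concentration tested, a lower number a stronger effect), compound 2 gives 81.3%, the highest of the two numbers shown; its nearest neighbour is compound 1, which gives 40.7%. The only step shown between them, a number 40.6 percentage points higher from compound 1 to compound 2 (beyond the scatter), is large and beyond the scatter.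

Compound 3, `CC(=O)Nc1nc(-c2cccc(NS(=O)(=O)c3ccc(C#CC4CCCCC4)cc3)c2)cs1`, is not yet measured in this assay. It differs from compound 2 in one place: cyclohexyl in place of hydroxymethyl on a triple-bonded carbon. The step from compound 1 to compound 2 bears on this change, since it arose from hydroxy in place of pentyl on a saturated chain carbon bound to a triple-bonded carbon and was large. Compound 3 takes the hydroxy away again and puts a carbon ring on the triple-bonded carbon, so the step is expected to run back the other way, a number 36.3 percentage points lower from compound 2 to compound 3 (beyond the scatter), toward the level of compound 1. Compound 3 is therefore expected to give 45%, between 28% and 70%.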

Compound 3, a percentage reported as activity, at one concentration (the size of the read-out at that concentration, not a potency): 52.3%
Compound 3: middle estimate off by 7.3 percentage points, on the low side; the range from low to high includes it.
By their numbers in this assay, from the lowest: compound 1; then compound 3; then compound 2.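

In this assay the hydroxymethyl group proves not to be needed at this position: with cyclohexyl on the triple-bonded carbon the effect at the concentration tested grows, with a number 29 percentage points lower from compound 2 to compound 3 (beyond the scatter) and no hydrogen-bond donor or acceptor left on the group. The ring does not fully match the open chain, as a number 11.6 percentage points higher from compound 1 to compound 3 (beyond the scatter) shows, so on this evidence hexyl gives the stronger effect of the two carbon groups, though only by a modest step. No measurement shown explains either step.

Compounds 2 and 3 differ in both the hydroxy and the carbon ring, so a plain methyl or a hydroxy on the cyclohexyl ring would be needed to separate the two. As far as these compounds go, how a smaller cyclopropyl ring, a phenyl ring or an amine would fare at this position remains open.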